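A few compounds are considered here, and "the series" means these few. Any claim that something is new, unique, unknown or untested is made for them only; others in the source may bear on it.

Measured so far in a functional assay on MM1.S cells (Homo sapiens) for antiproliferative activity, read by luminescence, with a stated time of 72 h (on this read-out higher numbers stand for weaker inhibition and lower numbers for stronger inhibition), are two compounds:

- compound 1 `CC(C)(C)OC(=O)Oc1ccc(Cn2ccnc2)c2cccnc12` gives 1800 nM here
- compound 2 `CC(C)(CCl)C(=O)Oc1ccc(Cn2ccnc2)c2cccnc12` gives 3600 nM here

On these numbers compound 2 stands level with compound 1, since the whole gap between them is a 2.0-fold higher number from compound 1 to compound 2 (0.30 log units; within the scatter) and the pair cannot be ranked.

Compound 3 `O=C(Oc1ccc(Cn2ccnc2)c2cccnc12)c1ccccc1` has not yet been measured. Its difference from compound 2 is phenyl in place of 1-(chloromethyl)-1-methylethyl on a carbonyl carbon and, in short, it has phenyl in place of 1-(chloromethyl)-1-methylethyl on a carbonyl carbon.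

Among the measured compounds shown here, one measured step bears on this change. It sits on the same carbonyl carbon, where 1-(chloromethyl)-1-methylethyl took the place of tert-butoxy. For the measured compounds named here, no measured compound carries phenyl there, so the support is thin. On the strength of a 2.0-fold higher number from compound 1 to compound 2 (0.30 log units; within the scatter) alone, no step beyond the scatter, in either direction, is expected in this assay for this exchange.

The expected change is a 1.3-fold lower number from compound 2 to compound 3 (0.11 log units; within the scatter) as estimated here. For compound 3 the estimate is 2800 nM with a range from 1000 nM to 7500 nM as the expected span.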

Compound 3, half-maximal inhibitory concentration: 2900 nM
Estimate against measurement, compound 3: 1.0-fold (0.02 log units) below, and the stated range covers the measured number.
By their numbers in this assay, from the lowest: compounds 1, 3 and 2 (each within the scatter of the next).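

In this assay, the carbonyl carbon now carries a ring, and phenyl in place of 1-(chloromethyl)-1-methylethyl gives a 1.2-fold lower number from compound 2 to compound 3 (0.09 log units; within the scatter) and so no readable shift. Phenyl in place of tert-butoxy likewise gives a 1.6-fold higher number from compound 1 to compound 3 (0.21 log units; within the scatter) and thus extends what the earlier pair suggested: in these three compounds, an open-chain group with chlorine, one without it and one six-membered aromatic ring of carbon only all leave the numbers inseparable, so this carbonyl carbon accepts all three groups without a step beyond the scatter. No measurement available here bears on why these three numbers lie so close together.

The three compounds leave open whether an amine, a carboxylic acid or a longer chain in this same place on the carbonyl carbon would produce a step beyond the scatter, in either direction. Going by these compounds, it also remains open whether a methoxy or chloro group on the phenyl ring of compound 3, or a nitrogen in place of the oxygen next to a carbonyl group, would change the number in this assay.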